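Replacing 2,4-dimethylphenyl with 2-chlorophenyl in compound 2

The compounds below may be only part of what the source reports. "The series", "measured", "known", "first", "only" and "open" are said of these compounds alone.

Going by the values given here, compound 2 `Cc1ccc(N2CCN(C(=O)c3oc(C)nc3-c3ccccc3)CC2)c(C)c1` stands at 101 nM in a functional assay on HL-60 cells (Homo sapiens) for inhibition, read by MTT assay, with a stated time of 72 h (on this read-out lower numbers stand for stronger inhibition and higher numbers for weaker inhibition), and holds the higher of the two numbers so far, while compound 1 `Cc1nc(-c2ccccc2)c(C(=O)N2CCN(c3cccc(C)c3C)CC2)o1` reaches 35 nM on the same core. Among the compounds with values here, the only measured step is a 2.9-fold higher number from compound 1 to compound 2 (0.46 log units; beyond the scatter) when 2,4-dimethylphenyl takes the place of 2,3-dimethylphenyl on an amine nitrogen in a ring. That single step shows that a change in this phenyl group can move the number. Compound 3 `Cc1nc(-c2ccccc2)c(C(=O)N2CCN(c3ccccc3Cl)CC2)o1` is altered at the same place, where 2-chlorophenyl replaces 2,4-dimethylphenyl on an amine nitrogen in a ring, and the count of the change is 2-chlorophenyl in place of 2,4-dimethylphenyl on an amine nitrogen in a ring for comparison. Within the data shown here, no compound with a chlorine has been measured yet, so a 2.9-fold higher number from compound 1 to compound 2 (0.46 log units; beyond the scatter) is the only guide to size. The direction leans toward a lower number since compound 2 at 101 nM is the higher of the two values. The expected change is a modest one, estimated as a 2.2-fold lower number from compound 2 to compound 3 (0.35 log units; beyond the scatter) in this assay with real uncertainty. Compound 3 is estimated at 45 nM with an expected range from 15 nM to 130 nM for now.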

Compound 3, half-maximal inhibitory concentration: 124 nM
The estimate for compound 3 lay 2.8-fold (0.44 log units) below the measured number; the range from low to high includes it.
By their numbers in this assay, from the lowest: compound 1; then compounds 2 and 3 (each within the scatter of the next).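

In this assay, putting 2-chlorophenyl in place of 2,4-dimethylphenyl on the amine nitrogen gives a 1.2-fold higher number from compound 2 to compound 3 (0.09 log units; within the scatter), so these two groups cannot be told apart here, even though one carries a chlorine and the other two methyl groups. The same 2-chlorophenyl group in place of 2,3-dimethylphenyl gives a 3.5-fold higher number from compound 1 to compound 3 (0.55 log units; beyond the scatter), which leaves compound 1 as the only one of the three clearly apart from the others, since its steps to both lie beyond the scatter. Nothing measured here explains why 2,3-dimethylphenyl stands apart from the other two groups.

The compounds shown leave open whether a plain phenyl, a methoxyphenyl or a pyridine ring on that amine nitrogen would group with compound 1 or with compound 2 and compound 3. As far as these compounds go, it also remains open whether both methyl groups of 2,3-dimethylphenyl are needed for the lower number of compound 1, a question that a ring with a single methyl group could help to settle.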